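The compounds below may be only part of what the source reports. "The series", "measured", "known", "first", "only" and "open" are said of these compounds alone.

Compound 2 `[O-][n+]1nc(NC2CC2)[n+]([O-])c2ccccc21` was tested in a functional assay on PC-3 cells (Homo sapiens) for cytotoxicity, read by MTT assay, with a stated time of 48 h (a lower number here means a stronger inhibitor, a higher number a weaker inhibitor), alongside compound 1 `COc1ccc(Nc2n[n+]([O-])c3ccccc3[n+]2[O-])cc1`. In this assay compound 2 gives 15900 nM, while compound 1 gives 12000 nM; the two numbers sit within the usual scatter of each other, so neither compound can be set apart from the other. Compound 3 `[O-][n+]1nc(Nc2ccccc2)[n+]([O-])c2ccccc21` has not yet been measured. It differs from compound 2 by a single change: phenyl in place of cyclopropyl on a nitrogen on an aromatic ring. With compound 1 carrying an aryl group on the same nitrogen, compound 3 is expected to show a step of a 1.3-fold lower number from compound 2 to compound 3 (0.12 log units; within the scatter), that is, nothing beyond the scatter. For compound 3 the estimate is 12000 nM, with a range from 5000 nM to 30000 nM.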

Compound 3, half-maximal inhibitory concentration: 17000 nM
Compound 3: the middle estimate sits 1.4-fold (0.15 log units) below what was measured, within the range that was stated.
By their numbers in this assay, from the lowest: compounds 1, 2 and 3 (each within the scatter of the next).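

In this assay, phenyl in place of cyclopropyl on a nitrogen on an aromatic ring gives a 1.1-fold higher number from compound 2 to compound 3 (0.03 log units; within the scatter) and so shows that this nitrogen carries either ring with no readable difference. Hydrogen in place of methoxy on an aromatic carbon gives a 1.4-fold higher number from compound 1 to compound 3 (0.15 log units; within the scatter) and so adds that the methoxy group on the phenyl ring makes no readable difference either. Nothing measured here offers an explanation for these results. Still open, as far as these compounds go, is whether a longer alkyl chain, an amine or a carboxylic acid at either place would give a step beyond the scatter.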